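The compounds below may be only part of what the source reports. "The series", "measured", "known", "first", "only" and "open" are said of these compounds alone.

Measured compounds:
compound 1 `Nc1nn(C(=O)Nc2ccc(Cc3ccccc3)cc2)c2ccccc12`, > 100000 nM
compound 2 `Nc1nn(C(=O)Nc2ccc(Cc3ccccc3)cc2)c2ccc(Cl)cc12`, > 100000 nM

In a functional assay on A549 cells (Homo sapiens) for antiproliferative activity, read by sulforhodamine B assay, with a stated time of 48 h (a higher number here means that more compound is tolerated, a lower number that less compound is tolerated), compound 1 gives only a limit, > 100000 nM. In this assay compound 2 likewise gives only a limit, > 100000 nM. The one measured step, a step that the two limits leave unreadable from compound 1 to compound 2, is therefore not readable in size, and compound 2 stands at the same limit as compound 1, as shown by the limit of > 100000 nM in this assay, at which 2 of the 2 values shown sit.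

Compound 3 `Nc1ccc2c(c1)c(N)nn2C(=O)Nc1ccc(Cc2ccccc2)cc1` differs from compound 2 by amino in place of chloro on an aromatic carbon. Within the data shown here, the only step that bears on a change at this carbon is the unreadable one from compound 1 to compound 2, so no direction and no size can be taken from it. Compound 3 is therefore expected to stay at the limit as well, with an estimated step that the limit leaves unreadable from compound 2 to compound 3 of no readable size. For compound 3 the estimate in this assay is 150000 nM, within 30000 nM to 1000000 nM.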

Compound 3, concentration lethal to 50% of the cells: > 100000 nM
Compound 3: no number, only a limit (the forecaster's own chance of this, stated with the estimate: 80%); the middle value lies beyond the limit too.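

Compound 3 also gives only a limit in this assay, so no step among compound 1, compound 2 and compound 3 can be read, and all three sit at one ceiling: the limit of > 100000 nM in this assay, at which 3 of the 3 values shown sit.

What the compounds shown leave open is whether any change on this aromatic carbon alters the lethal concentration at all.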